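The source may hold more compounds than are shown below. What is called first, only, known or untested is meant among the compounds shown, and "the series" means these compounds.

The study concerns a small family of amides that share one core and differ only in the aryl group on the amide-type nitrogen. Compound 1 `CCCCc1ccc(NC(=O)COc2cc(C)nc3ccc(OC)cc23)cc1` carries a 4-butylphenyl group, compound 2 `COc1ccc2nc(C)cc(OCC(=O)Nc3ccc(C)c(C)c3)c2c1` a 3,4-dimethylphenyl group, and compound 3 `COc1ccc2nc(C)cc(OCC(=O)Nc3ccc4c(c3)CCCC4)c2c1` a ring-fused group. All three were measured in a physicochemical assay for solubility, read by HPLC, measured as thermodynamic solubility, with a stated time of 24 h, at pH 1.5; on this read-out higher numbers stand for higher solubility and lower numbers for lower solubility. Compound 1 gives 240000 nM, compound 2 gives 80000 nM and compound 3 gives 90000 nM. Compound 2 and compound 3 lie within the usual scatter of each other, so nothing separates them; compound 1 stands higher than compound 2 by a margin beyond that scatter.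

Compound 4 `CCCc1ccc(NC(=O)COc2cc(C)nc3ccc(OC)cc23)cc1` has not yet been measured in this assay. It differs from compound 2 in one place: 4-propylphenyl in place of 3,4-dimethylphenyl on an amide-type nitrogen. With a single carbon chain on the ring, compound 4 sits structurally between compound 2 and compound 1.

Compound 4 is expected to give a higher number than compound 2, because compound 1, which also carries a straight chain on that ring, gives 240000 nM. The step from compound 2 to compound 4 is estimated at a 1.9-fold higher number from compound 2 to compound 4 (0.27 log units; within the scatter), upward and somewhat beyond the scatter. For compound 4 the expected solubility is 150000 nM, with a range from 60000 nM to 350000 nM.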

Compound 4, solubility: 260000 nM
For compound 4 the middle estimate is 1.7-fold (0.24 log units) below the measured one, within the range that was stated.
By their numbers in this assay, from the lowest: compounds 2 and 3 (each within the scatter of the next); then compounds 1 and 4 (each within the scatter of the next).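

In this assay, putting 4-propylphenyl in place of 3,4-dimethylphenyl on the amide-type nitrogen gives a 3.3-fold higher number from compound 2 to compound 4 (0.51 log units; beyond the scatter) and so shows that this position responds to a change of aryl group, by a step larger than the usual scatter of repeated measurements. The comparison of the two straight chains, with hydrogen in place of methyl on a saturated chain carbon, three bonds along the chain from an aromatic carbon, gives a 1.1-fold higher number from compound 1 to compound 4 (0.03 log units; within the scatter) and so shows that this read-out does not separate the 4-butylphenyl and 4-propylphenyl groups. Nothing available here explains why the first change shifts the number while the second does not.

Going by these compounds alone, with only one step leading from the two-methyl ring to a straight chain, it stays open whether a single methyl or ethyl group on the ring would give a number close to that of compound 2 or close to that of compound 4. A longer chain such as pentyl, or a chain ending in an amine or a carboxylic acid, also remains an open case at this position.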